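The compounds below may be only part of what the source reports. "The series", "measured", "known", "first", "only" and "open" are said of these compounds alone.

In an ADME assay on the whole organism for metabolic stability, with Canis familiaris (Canis lupus familiaris) as the target, read by LC-MS, at a dose of 1 mg/kg by the intravenous route (a higher number here means that the compound lasts longer, a lower number that the compound disappears faster), compound 1 (`Cc1cc(C(=O)N[C@H]2CCCCC/C=C\[C@@H]3C[C@@]3(C(=O)NS(=O)(=O)C3CC3)NC(=O)[C@@H]3C[C@@H](Oc4nc5cc(F)ccc5nc4C)CN3C2=O)no1`) gives 2 h, compound 2 (`Cc1cc(C(=O)N[C@H]2CCCCC/C=C\[C@@H]3C[C@@]3(C(=O)NS(=O)(=O)C3CC3)NC(=O)[C@@H]3C[C@@H](Oc4nc5ccccc5nc4C(F)(F)F)CN3C2=O)no1`) gives 1 h and compound 3 (`Cc1cc(C(=O)N[C@H]2CCCCC/C=C\[C@@H]3C[C@@]3(C(=O)NS(=O)(=O)C3CC3)NC(=O)[C@@H]3C[C@@H](Oc4nc5cc(F)ccc5nc4C(F)(F)F)CN3C2=O)no1`) gives 3.5 h. Compound 3 stands clear of only one of the others: trifluoromethyl in place of methyl gives a 1.8-fold higher number from compound 1 to compound 3 (0.24 log units; within the scatter), whereas fluoro in place of hydrogen gives a 3.5-fold higher number from compound 2 to compound 3 (0.54 log units; beyond the scatter). Compound 4 (`Cc1cc(C(=O)N[C@H]2CCCCC/C=C\[C@@H]3C[C@@]3(C(=O)NS(=O)(=O)C3(C)CC3)NC(=O)[C@@H]3C[C@@H](Oc4nc5cc(F)ccc5nc4C(F)(F)F)CN3C2=O)no1`) carries methyl in place of hydrogen on a saturated ring carbon, methyl in place of hydrogen on a saturated ring carbon, turning cyclopropylsulfonyl into (1-methylcyclopropyl)sulfonyl. Both measured steps fall on an aromatic carbon, so neither gives a size for this change. The expectation therefore rests on compound 3 itself, at 3.5 h, with no step beyond the scatter expected in this assay. The expected step is no change at the digits printed from compound 3 to compound 4 (within the scatter). For compound 4 the estimate is 3.5 h, with an expected range of 1.8 h to 7 h.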

Compound 4, half-life: 2.9 h
Compound 4: the middle estimate sits 1.2-fold (0.08 log units) above what was measured; low and high end bracket the measured number.
By their numbers in this assay, from the lowest: compounds 2, 1, 4 and 3 (each within the scatter of the next, the first and the last beyond it).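

In this assay, methyl in place of hydrogen on a saturated ring carbon gives a 1.2-fold lower number from compound 3 to compound 4 (0.08 log units; within the scatter), the only step shown at this position, and it lies within the scatter. Turning cyclopropylsulfonyl into (1-methylcyclopropyl)sulfonyl is therefore tolerated on this one pair of compounds, unlike the fluoro step at the aromatic carbon, which lies beyond the scatter. No measurement shown explains this result. The compounds shown leave open whether an ethyl or an aminomethyl group on the same ring carbon would also stay within the scatter. They also leave open whether the methyl would do so on the core of compound 1 or compound 2.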